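Series notes: from compound 3 toward compound 4

The compounds below may be only part of what the source reports. "The series", "measured", "known", "first", "only" and "open" are said of these compounds alone.

Three compounds have numbers in an in vitro assay on HEK385-7 cells for displacement of a labelled ligand from prostaglandin D2 receptor 2 (Homo sapiens); a lower number here means a stronger inhibitor, a higher number a weaker inhibitor. Compound 1 `O=C(O)Cc1sc(C(c2ccccc2)c2ccccc2)nc1-c1ccccc1` gives 570 nM, compound 2 `O=C(O)Cc1sc(C(c2ccccc2)c2ccc(F)c(F)c2)nc1-c1ccc(F)cc1` gives 10 nM, and compound 3 `N#Cc1ccc(-c2nc(C(c3ccc(F)cc3)c3ccc(F)cc3)sc2CC(=O)O)cc1` gives 150 nM. Compound 3 therefore stands second highest of the three, closer to compound 1 than to compound 2, and both gaps lie beyond the scatter. Compound 4 `O=C(O)Cc1sc(C(c2ccc(F)cc2)c2ccc(F)cc2)nc1-c1ccnc(Cl)c1` has not yet been measured. It differs from compound 3 in one place: 2-chloropyridin-4-yl in place of 4-cyanophenyl on an aromatic carbon. Going by the values given here, no step between measured compounds isolates this change, so the expectation rests on the spread of the series. A moderate downward step is expected, a 2.5-fold lower number from compound 3 to compound 4 (0.40 log units; beyond the scatter), since compound 2 with 10 nM shows how low the numbers reach within this series. Compound 4 is estimated at 60 nM in this assay, between 20 nM and 200 nM.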

Compound 4, half-maximal inhibitory concentration: 3.1 nM
Estimate against measurement, compound 4: 19-fold (1.29 log units) above; the whole stated range lies above it.
By their numbers in this assay, from the lowest: compound 4; then compound 2; then compound 3; then compound 1.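

At the aromatic carbon next to the ring nitrogen, 2-chloropyridin-4-yl in place of 4-cyanophenyl gives a 48-fold lower number from compound 3 to compound 4 (1.68 log units; beyond the scatter) in this assay. Going by these compounds alone, this is the first step that isolates one place, and it shows that this position alone can shift the number by a large margin while the rest of compound 3 stays fixed. Nothing on hand bears on the reason for a step of this size.

The change replaces the ring and its substituent together, so the contributions of the ring nitrogen and the chlorine remain unseparated. Unsubstituted pyridin-4-yl, or a methoxy group in place of the chlorine, would be needed to tell them apart.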